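Extending the alkoxy chain on the shared core

The compounds below may be only part of what the source reports. "The series", "measured", "known", "first", "only" and "open" are said of these compounds alone.

Measured compounds:
compound 1 `CCCN(CCC)c1nc(C(C)(C)C)ccc1CNC(=O)C(C)c1ccc(NS(C)(=O)=O)c(F)c1`: 2.5 nM
compound 2 `CC(C(=O)NCc1ccc(C(C)(C)C)nc1N1CCCC1)c1ccc(NS(C)(=O)=O)c(F)c1`: 1.2 nM
compound 3 `CCOc1nc(C(C)(C)C)ccc1CNC(=O)C(C)c1ccc(NS(C)(=O)=O)c(F)c1`: 14.8 nM

Of the three compounds measured in an assay on cells for antagonist activity at transient receptor potential cation channel subfamily V member 1 (Homo sapiens), read by FLIPR and calcium flux, with a stated time of 6 min (a higher number here means a weaker inhibitor, a lower number a stronger inhibitor), compound 3 stands with the highest number. Its nearest neighbour is compound 1, with a 5.9-fold higher number from compound 1 to compound 3 (0.77 log units; beyond the scatter), and its furthest is compound 2, with a 12-fold higher number from compound 2 to compound 3 (1.09 log units; beyond the scatter). Both steps change only the group on the aromatic carbon of the shared core, and both show that this position moves the number well beyond the scatter. The step of a 2.1-fold lower number from compound 1 to compound 2 (0.32 log units; beyond the scatter) between the two amino variants is modest by comparison.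

Compound 4 `CCCCOc1nc(C(C)(C)C)ccc1CNC(=O)C(C)c1ccc(NS(C)(=O)=O)c(F)c1` differs from compound 3 by ethyl in place of hydrogen on a saturated chain carbon, two bonds along the chain from an oxygen on an aromatic ring. Among the compounds with values here, no measured step alters the alkoxy chain itself, so the two amino steps bear on it only indirectly: they show that a larger group on that carbon, as in compound 1, goes with a lower number than the ethoxy of compound 3. On that basis the step of a 1.9-fold lower number from compound 3 to compound 4 (0.27 log units; within the scatter) is expected to be small and toward a lower number, if beyond the scatter at all. Compound 4 is therefore estimated at 8 nM in this assay, with a range from 3 nM to 25 nM.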

Compound 4, inhibition constant: 0.9 nM
For compound 4 the middle estimate is 8.9-fold (0.95 log units) above the measured one; measured number outside the range, below it.
By their numbers in this assay, from the lowest: compounds 4 and 2 (each within the scatter of the next); then compound 1; then compound 3.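

In this assay, within the data shown here, the step of a 16-fold lower number from compound 3 to compound 4 (1.22 log units; beyond the scatter) is the first change made within the alkoxy chain itself, and it shows that ethyl in place of hydrogen at this saturated chain carbon can move the number as far as swapping the whole group on the aromatic carbon did. The high number of compound 3 therefore does not hold for oxygen-linked groups in general: butoxy lies within the scatter of pyrrolidin-1-yl, at a 1.3-fold lower number from compound 2 to compound 4 (0.12 log units; within the scatter), and goes beyond the dipropylamino group, at a 2.8-fold lower number from compound 1 to compound 4 (0.44 log units; beyond the scatter), so an amino group is not required for a low number among these compounds. No measurement given here explains why this change has so large an effect.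

With only ethoxy and butoxy in hand, the compounds shown cannot tell whether propoxy would fall midway between them, or whether a longer chain such as pentyloxy or hexyloxy would lower the number further or raise it again. They also leave open whether a branched chain such as isobutoxy or a ring-bearing one such as cyclopropylmethoxy would match the straight butoxy chain.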